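A few compounds are considered here, and "the series" means these few. Any claim that something is new, unique, unknown or untested is made for them only; others in the source may bear on it.

The measured compounds:

compound 1, `O=C(Nc1ccc(-c2cccc(Cl)c2)cn1)c1ccccc1`, 38%
compound 2, `O=C(Nc1ccc(-c2ccc(Cl)c(Cl)c2)cn1)c1ccccc1`, 4%
compound 3, `O=C(Nc1ccc(-c2ccccc2)cn1)c1ccc(Cl)cc1`, 0%

In an assay on isolated protein (Aquatica lateralis) for inhibition of Luciferin 4-monooxygenase (Luciola lateralis), read by a luciferase reporter, tested at 10 uM (a higher number here means more inhibition at the concentration tested (going by the name of the read-out), a lower number less inhibition), compound 1 gives 38%. Compound 2 differs from compound 1 by chloro in place of hydrogen on an aromatic carbon, and in this assay this made a number 34 percentage points lower from compound 1 to compound 2 (beyond the scatter). Compound 3 has the same atoms as compound 1 joined differently; the difference between the two cores is not broken down here. In this assay compound 3 gives 0%, the lowest of the three numbers, beyond the scatter from compound 1 but within the scatter of compound 2.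

Compound 4, `O=C(Nc1ccc(-c2ccccc2)cn1)c1ccc(Cl)c(Cl)c1`, differs from compound 3 by chloro in place of hydrogen on an aromatic carbon. This is the same kind of change as that from compound 1 to compound 2, yet the place is not the same: in compound 2 the entering chloro group is para to a large group, in compound 4 it is meta to a large group. In this assay the step is expected to be a number 3 percentage points higher from compound 3 to compound 4 (within the scatter), a small one, since compound 3 already gives 0% and a percentage of inhibition can hardly fall further; the large drop from compound 1 to compound 2 gives no sign that a second chloro group raises the number. Compound 4 is therefore expected to give about 3% in this assay, likely between 0% and 12%.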

Compound 4, a percentage reported as inhibition, at one concentration (the size of the read-out at that concentration, not a potency): 13%
Estimate against measurement, compound 4: 10 percentage points below; measured number above the stated range.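

In this assay, chloro in place of hydrogen on an aromatic carbon gave a number 13 percentage points higher from compound 3 to compound 4 (beyond the scatter), whereas the same kind of change gave a number 34 percentage points lower from compound 1 to compound 2 (beyond the scatter) on the other core, and the two steps do not agree: the same change on two cores in this assay, a number 34 percentage points lower (beyond the scatter) from compound 1 to compound 2 and a number 13 percentage points higher (beyond the scatter) from compound 3 to compound 4, 47 percentage points apart, beyond the scatter of two such steps. Within these compounds, then, the step seen on one core did not carry over to the other, in size or in direction, and a chloro group added on one core gives no safe estimate for the same change on the other. This does not show what sets the two steps apart: the core differs and so does the place where the chloro group enters, and with a single step on each core the two cannot be separated, nor can two steps show how the change would behave on any further core.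

The compounds shown leave open whether the difference follows the core or the place, which would take the same chloro change at the same place on both cores. They also leave open how a fluoro group, a methoxy group, an amine or a carboxylic acid at these places would read in this assay, on either core.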